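Cytotoxicity on Vero cells across a shared benzimidazole-free series

A few compounds are considered here, and "the series" means these few. Any claim that something is new, unique, unknown or untested is made for them only; others in the source may bear on it.

Compound 1 `CN(C)c1cc2[nH]c(C3CCCCC3)nc2cc1NC(=O)c1ccc(Br)cc1`: > 100 ug/mL in an ADME assay on Vero cells (Chlorocebus sabaeus) for cytotoxicity, read by resazurin assay, with a stated time of 3 days (on this read-out higher numbers stand for weaker inhibition and lower numbers for stronger inhibition), a limit of the assay.
Compound 2 `CCN(CC)c1cc2[nH]c(C3CCCCC3)nc2cc1NC(=O)c1ccc(N(C)C)cc1`: "not determined" (no result reported).
Compound 3 `CCOCCOC(=O)Nc1cc2nc(C3CCCCC3)[nH]c2cc1N1CCCC1`: > 100 ug/mL, a limit of the assay.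

Compound 2 stands without a single number in this assay. The two other values shown are limits, as the limit of > 100 ug/mL in this assay, at which 2 of the 3 values shown sit, records, so no number among the measured compounds places compound 2 against them. Compound 4 `CCc1ccc(C(=O)Nc2cc3nc(C4CCCCC4)[nH]c3cc2N(CC)CC)cc1` differs from compound 2 in one place: ethyl in place of dimethylamino on an aromatic carbon. Going by the values given here, with no measured step available, the change is expected to leave this assay within the usual scatter, in no clear direction. Compound 4 is therefore expected to give about 100 ug/mL, estimated between 30 ug/mL and 300 ug/mL, most likely reported only as a limit.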

Compound 4, half-maximal inhibitory concentration: > 100 ug/mL
Compound 4: only a limit was reported; the forecaster's own chance of this, stated with the estimate: 75%; the middle value sits exactly at the limit.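

Going by these compounds alone, compound 2 has no reported result, so no step from it to compound 4 can be read. Compound 4 gives > 100 ug/mL, a limit of the assay. Whether any change of group alters cytotoxicity stays open, as the values share one limit: the limit of > 100 ug/mL in this assay, at which 3 of the 4 values shown sit.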